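Cyclopropyl in Place of Methyl on a Difluorinated Aryl

The source may hold more compounds than are shown below. What is called first, only, known or untested is meant among the compounds shown, and "the series" means these compounds.

Measured compounds:
- compound 1, `N#Cc1ccc(Nc2ncc(Cc3c(F)cccc3F)o2)cc1`, 8000 nM
- compound 2, `Cc1cc(F)c(Cc2cnc(Nc3ccc(C#N)c(Cl)c3)o2)c(F)c1`, 31000 nM

Of the compounds shown here, two have been measured in an ADME assay on MT2 cells (Homo sapiens) for inhibition; on this read-out lower numbers stand for higher toxicity in this test and higher numbers for lower toxicity in this test. Compound 1 gives 8000 nM, while compound 2 gives 31000 nM. For the measured compounds named here, compound 2 thus stands at the highest of the two numbers; the only neighbour is compound 1, whose number is lower by a gap that lies beyond the usual scatter. Going by the values given here, the two compounds differ in more than one place, so no single step between them is drawn.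

Compound 3, `N#Cc1ccc(Nc2ncc(Cc3c(F)cc(C4CC4)cc3F)o2)cc1Cl`, has not yet been measured in this assay. It differs from compound 2 in one place: cyclopropyl in place of methyl on an aromatic carbon. The change adds two carbons and a small ring at a position flanked by the two fluoro groups, on the ring that carries the large group.

Among the compounds with values here, no measured step shows what this kind of exchange does in this assay. With the surrounding parts of compound 2 kept, the number of compound 3 is expected to land close to that of compound 2, and the step of a 1.4-fold lower number from compound 2 to compound 3 (0.15 log units; within the scatter) is expected to stay within or only slightly beyond the scatter, if anything towards a somewhat lower number. Compound 3 is accordingly estimated at 22000 nM, with a range from 8000 nM to 55000 nM.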

Compound 3, half-maximal cytotoxic concentration: 65000 nM
Estimate against measurement, compound 3: 3.0-fold (0.47 log units) below; measured number above the stated range.
By their numbers in this assay, from the lowest: compound 1; then compound 2; then compound 3.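

In this assay, for the compounds shown here, the exchange of methyl for cyclopropyl on an aromatic carbon, meta to two fluoro groups and para to a large group, gives a 2.1-fold higher number from compound 2 to compound 3 (0.32 log units; beyond the scatter) and so provides the first step at this position that differs in one place only. It shows that the read-out responds to a change here: the entering group, with its three heavy atoms and three-membered ring of carbon only, goes with a higher number and thus lower toxicity in this test, although the step is modest and lies only slightly beyond the usual scatter. Nothing at hand bears on why the number rises with this exchange.

This single step does not show whether the number depends on the ring itself or on the count of heavy atoms, and an ethyl group, an isopropyl group, a cyclobutyl ring or an amine on this aromatic carbon could separate these readings. It also leaves open whether the same exchange would give a step of similar size on a different parent compound.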